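This account rests on a few compounds, and the source may have more. Where it says the series, first, only, none or still open, it means among the compounds named here.

Compound 1 `COc1ccc(N(CC(=O)NCCCSc2ccccc2)C(=O)CCSC2=C(C)C(=O)c3ccccc3C2=O)cc1` and compound 2 `COc1ccc(N(CC(=O)NCCC[Se]c2ccccc2)C(=O)CCSC2=C(C)C(=O)c3ccccc3C2=O)cc1` share one core and differ only in a group hanging from a saturated chain: a group of 7 heavy atoms (6 carbon, 1 sulfur; one six-membered aromatic ring of carbon only) in place of a group of 7 heavy atoms (6 carbon, 1 selenium; one six-membered aromatic ring of carbon only), on a saturated chain carbon, three bonds along the chain from an amide-type nitrogen. In a functional assay on A-431 cells (Homo sapiens) for cytotoxicity, read by MTT assay, with a stated time of 24 h (a higher number here means a weaker inhibitor, a lower number a stronger inhibitor), compound 1 gives 17000 nM. In this assay compound 2 gives 17000 nM. The step of no change at the digits printed from compound 2 to compound 1 (within the scatter) shows that swapping selenium for sulfur in this part of the molecule leaves the read-out where it was.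

Compound 3 `COc1ccc(N(CC(=O)NCCC[Se]c2ccccc2)C(=O)C#Cc2ccccc2)cc1` carries a different core, and the difference between the two cores is not broken down here. For compound 3, this assay gives only a limit, not a number: >= 100000 nM. This is the situation described by the limit of >= 100000 nM in this assay, at which 1 of the 3 values shown sits.

Compound 4 `COc1ccc(N(CC(=O)NCCCSc2ccccc2)C(=O)C#Cc2ccccc2)cc1` is the still unmeasured partner of compound 3, and it carries the same kind of change that turns compound 2 into compound 1: a group of 7 heavy atoms (6 carbon, 1 sulfur; one six-membered aromatic ring of carbon only) in place of a group of 7 heavy atoms (6 carbon, 1 selenium; one six-membered aromatic ring of carbon only), on a saturated chain carbon, three bonds along the chain from an amide-type nitrogen. The two places are described in the same words, so the change is the same one made on a different core.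

The expectation for compound 4 rests on compound 2 and compound 1, where no change at the digits printed from compound 2 to compound 1 (within the scatter) stayed within the scatter. Since that change did not move the read-out on the first core, it is expected not to move it on the second core either, and the assay is expected to report a limit again for compound 4 rather than a number. Compound 4 is therefore estimated at 100000 nM, with a range from 40000 nM to 300000 nM. The expected step is a number no higher from compound 3 to compound 4 (the limit leaves the size open).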

Compound 4, half-maximal inhibitory concentration: >= 100000 nM
Compound 4 ended at the assay's limit; the forecaster's own chance of this, stated with the estimate: 80%; the middle value lies on the limit itself.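

In this assay, compound 3 and compound 4 each give a limit and not a number, so no step between them can be read: the limit of >= 100000 nM in this assay, at which 2 of the 4 values shown sit.

The compounds shown leave open whether replacing the selenium-containing group with phenylsulfanyl changes the read-out at all on the core of compound 3, and what actual number either compound would give.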